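The source may hold more compounds than are shown below. What is called first, only, known or untested is meant among the compounds shown, and "the series" means these compounds.

In a functional assay on MOLT-4 cells (Homo sapiens) for antiproliferative activity, read by MTT assay, with a stated time of 3 days (on this read-out higher numbers stand for weaker inhibition and lower numbers for stronger inhibition), compound 1 `Cc1ccc(C#Cc2cn(C/C=C\CN3C(=O)c4ccccc4C3=O)c(=O)[nH]c2=O)cc1` gives 266000 nM, the higher of the two numbers in hand, while compound 3 `O=C1c2ccccc2C(=O)N1C/C=C/Cn1cc(C#CCCc2ccccc2)c(=O)[nH]c1=O` gives 39000 nM. Compound 2 `CCCCCC#Cc1cn(C/C=C/CN2C(=O)c3ccccc3C2=O)c(=O)[nH]c1=O` gives only a limit of this assay, > 500000 nM. The change from compound 1 to compound 4 `CCCCc1ccc(C#Cc2cn(C/C=C\CN3C(=O)c4ccccc4C3=O)c(=O)[nH]c2=O)cc1` is propyl in place of hydrogen on a saturated chain carbon bound to an aromatic carbon. Going by the values given here, the one measured one-place step, an at least 12-fold lower number from compound 2 to compound 3 (1.10 log units; beyond the scatter), puts phenyl in place of propyl and so bears on the present change only loosely, since here propyl is added rather than removed. A modest step in this assay is therefore expected, its direction uncertain. Compound 4 is estimated at 150000 nM, with a range from 40000 nM to 500000 nM, which corresponds to a 1.8-fold lower number from compound 1 to compound 4 (0.25 log units; within the scatter).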

Compound 4, half-maximal inhibitory concentration: 31000 nM
For compound 4 the middle estimate is 4.8-fold (0.68 log units) above the measured one, and the stated range ends above it.
By their numbers in this assay, from the lowest: compounds 4 and 3 (each within the scatter of the next); then compound 1. At a limit, above all of these: compound 2.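

In this assay, the change of 4-methylphenyl to 4-butylphenyl gives an 8.6-fold lower number from compound 1 to compound 4 (0.93 log units; beyond the scatter), so this place on the shared core responds to the added propyl. Going by these compounds alone, the only earlier step, from compound 2 to compound 3, involved a different chain and said nothing about this place. No measurement shown accounts for the size of this step. From the compounds shown here alone, it remains open whether a longer chain would lower the number further. Going by these compounds, it is equally open whether an amine or a carboxylic acid at this saturated chain carbon would preserve the step.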